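The source may hold more compounds than are shown below. What is called first, only, known or untested is meant among the compounds shown, and "the series" means these compounds.

Measured so far:
- compound 1 `CC(C)(C)OC(=O)NCNC(=O)CN1CN(c2ccccc2)C2(CCN(C(=O)c3ccc(C4CCCCC4)cc3)CC2)C1=O`: 1700 nM
- compound 2 `COC(=O)CCNC(=O)CN1CN(c2ccccc2)C2(CCN(C(=O)c3ccc(C4CCCCC4)cc3)CC2)C1=O`: 12900 nM

These two compounds share one core and differ only in the side chain hanging from the amide-type nitrogen. Within the data shown here, in an assay on HEK293 cells for displacement of a labelled ligand from NPC1-like intracellular cholesterol transporter 1 (Homo sapiens) (on this read-out lower numbers stand for stronger inhibition and higher numbers for weaker inhibition), compound 2 gives the higher of the two numbers, and the only step available, a 7.6-fold higher number from compound 1 to compound 2 (0.88 log units; beyond the scatter), shows that it binds more weakly than compound 1.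

Compound 3 `NCCNC(=O)CN1CN(c2ccccc2)C2(CCN(C(=O)c3ccc(C4CCCCC4)cc3)CC2)C1=O` has not yet been measured. It is made from compound 2 by amino in place of methoxycarbonyl on a saturated chain carbon, two bonds along the chain from an amide-type nitrogen. Among the measured compounds shown here, this change is not the same as the one between compound 1 and compound 2, which swapped one carbon-rich ester-bearing chain for a carbamate-bearing one; no measured step exchanges an ester for a bare amino group, so the step from compound 1 to compound 2 bears on it only loosely, by showing that this side chain is a place where changes do move the number. For the measured compounds named here, with that as the only guide, the expectation for compound 3 is a step of uncertain direction and size, a 1.8-fold lower number from compound 2 to compound 3 (0.27 log units; within the scatter). Compound 3 is therefore estimated at 7000 nM, within a wide range from 1500 nM to 30000 nM.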

Compound 3, half-maximal inhibitory concentration: 3800 nM
Beside the measured number, compound 3's estimate is 1.8-fold (0.27 log units) above it, and the stated range covers the measured number.
By their numbers in this assay, from the lowest: compound 1; then compound 3; then compound 2.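

Replacing methoxycarbonyl with amino at this spot on the chain gives a 3.4-fold lower number from compound 2 to compound 3 (0.53 log units; beyond the scatter) in this assay, so the ester end of compound 2 is not needed for binding, and a single nitrogen atom in its place does better than those four heavy atoms. The amino chain still falls short of the carbamate-bearing chain, with a 2.2-fold higher number from compound 1 to compound 3 (0.35 log units; beyond the scatter) as the gap, and this step too lies beyond the usual scatter, so the three side chains give three distinguishable numbers rather than two levels. Nothing measured here explains why the amino group and the tert-butoxycarbonyl-capped chain rank as they do.

As far as these compounds go, whether the gain in compound 3 comes from having an amino group at the chain end or simply from losing the methyl ester remains open, and a carboxylic acid or an amide at the same place would help to separate the two. It is also unknown how the number would respond to a dimethylamino group at the chain end, or to a longer chain carrying the same amine.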